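Swapping the amide aryl group on a chromone cinnamamide

The source may report more compounds than this note shows. Statements on the series, on what has been measured and on what is new or still open speak of the compounds shown alone.

Measured so far, all in a functional assay on L02 cells (Homo sapiens) for inhibition, read by MTT assay, with a stated time of 48 h; on this read-out lower numbers stand for stronger inhibition and higher numbers for weaker inhibition:
Compound 1, `COc1ccc2c(=O)c(/C=C/C(=O)Nc3cc(C)ccc3C)coc2c1`, gives > 200000 nM, which is a limit of the assay.
Compound 2, `COc1ccc2c(=O)c(/C=C/C(=O)NCc3ccc(F)cc3)coc2c1`, gives > 200000 nM, also a limit.
Compound 3, `COc1ccc2c(=O)c(/C=C/C(=O)Nc3ccccc3OC)coc2c1`, gives > 200000 nM, again a limit.

Compound 3 therefore stands at the limit, like both others, as the limit of > 200000 nM in this assay, at which 3 of the 3 values shown sit, records. Compound 4, `COc1ccc2c(=O)c(/C=C/C(=O)Nc3ccc(F)cc3)coc2c1`, differs by 4-fluorophenyl in place of 2-methoxyphenyl on an amide-type nitrogen. The steps bearing on this are a step that the two limits leave unreadable from compound 1 to compound 3 and a step that the two limits leave unreadable from compound 2 to compound 3; a step that the two limits leave unreadable from compound 1 to compound 2 is likewise unreadable. None gives a readable size, so no direction can be drawn from them. Compound 4 is expected to sit near the same limit, with an estimated 250000 nM and a range from 100000 nM to 600000 nM. The expected step is a step that the limit leaves unreadable from compound 3 to compound 4, most likely again reported only as a limit.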

Compound 4, half-maximal inhibitory concentration: > 200000 nM
Compound 4 ended at the assay's limit; the forecaster's own chance of this, stated with the estimate: 80%; the middle value lies beyond the limit too.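

No size can be read for the steps to compound 4 from compound 1, compound 2 or compound 3, because all four compounds stop at the same limit: the limit of > 200000 nM in this assay, at which 4 of the 4 values shown sit.

The compounds shown leave open how strongly each one actually inhibits, and whether changing the group on the amide nitrogen makes any difference.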